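A few compounds are considered here, and "the series" means these few. Any claim that something is new, unique, unknown or untested is made for them only; others in the source may bear on it.

Measured compounds in a functional assay on A549 cells (Homo sapiens) for cytotoxicity, read by sulforhodamine B assay, with a stated time of 72 h; on this read-out lower numbers stand for stronger inhibition and higher numbers for weaker inhibition:
Compound 1 `Nc1sc(-c2ccccc2)c(-c2ccc(Cl)cc2)c1C(=O)NC1CC1` gives 4300 nM.
Compound 2 `Nc1sc(-c2ccc(Cl)cc2)c(-c2ccc(Cl)cc2)c1C(=O)NC1CC1` gives 1950 nM.
Compound 3 `Nc1sc(-c2ccc([N+](=O)[O-])cc2)c(-c2ccc(Cl)cc2)c1C(=O)NC1CC1` gives "not determined" (no result reported), so no number is reported for it.

Compound 2 stands at the lowest of the two numbers available; the only step shown, a 2.2-fold lower number from compound 1 to compound 2 (0.34 log units; beyond the scatter), separates it from compound 1 and goes beyond the scatter. Compound 3 adds no number to this comparison.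

Compound 4 `Nc1sc(-c2ccc(Cl)cc2)c(-c2ccc(Cl)cc2)c1C(=S)NC1CC1` differs from compound 2 in a single place: a group of 6 heavy atoms (4 carbon, 1 nitrogen, 1 sulfur; one three-membered non-aromatic ring of carbon only) in place of a group of 6 heavy atoms (4 carbon, 1 nitrogen, 1 oxygen; one three-membered non-aromatic ring of carbon only), on an aromatic carbon. For the measured compounds named here, no measured step touches this part of the shared core, since the one step on record concerns a chloro group on an aromatic carbon elsewhere. With nothing to point either way, the change is expected to give a step of no change at the digits printed from compound 2 to compound 4 (within the scatter) in this assay, that is, none beyond the scatter. Compound 4 is therefore estimated at 1950 nM, with a likely range from 650 nM to 5900 nM.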

Compound 4, half-maximal inhibitory concentration: 8280 nM
The estimate for compound 4 lay 4.2-fold (0.63 log units) below the measured number; measured number outside the range, above it.
By their numbers in this assay, from the lowest: compound 2; then compounds 1 and 4 (each within the scatter of the next).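

In this assay, sulfur in place of the carbonyl oxygen of the cyclopropylcarbamoyl group gives a 4.2-fold higher number from compound 2 to compound 4 (0.63 log units; beyond the scatter), so this position, untouched by the earlier chloro step, responds to the exchange. For the compounds shown here, both groups keep the same three-membered ring of carbon, which leaves the oxygen-to-sulfur exchange as the only difference in this pair. Nothing measured here accounts for the higher number. From the compounds shown here alone, it remains open whether a longer chain or a morpholine in place of the cyclopropyl ring would preserve the number of compound 2, and whether the same exchange would act alike on compound 1.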